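The source may hold more compounds than are shown below. What is called first, only, known or untested is meant among the compounds shown, and "the series" means these compounds.

Compound 2 `O=C(NCc1ccc(C(F)(F)F)nc1N1CCCCC1)Nc1cccc2c(=O)[nH]ccc12` is one of three compounds, all built around the same urea-linked core, whose agonist activity was examined in an assay on CHO cells for agonist activity at transient receptor potential cation channel subfamily V member 1 (Homo sapiens); a lower number here means that less compound is needed, a higher number that more compound is needed for the effect. Compound 2 gives 13.2 nM in this assay. Compound 3 `O=C(NCc1ccc(C(F)(F)F)nc1N1CCC(Cc2ccccc2)CC1)Nc1cccc2c(=O)[nH]ccc12`, which carries a benzyl on a saturated ring carbon of the piperidine, gives 5.81 nM; the step of a 2.3-fold lower number from compound 2 to compound 3 (0.36 log units; beyond the scatter) is modest but goes beyond the scatter, so compound 2 stands with the higher of the two reported numbers. Compound 1 `CC1CCN(c2nc(C(F)(F)F)ccc2CNC(=O)Nc2ccc3cc[nH]c(=O)c3c2)CC1`, which differs from both in its core and in its piperidine substitution, is reported as "not active" (no number reported), with no number given.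

Compound 4 `O=C(NCc1ccc(C(F)(F)F)nc1SC1CCCCC1)Nc1cccc2c(=O)[nH]ccc12` has not yet been measured. It differs from compound 2 in one place: cyclohexylsulfanyl in place of piperidin-1-yl on an aromatic carbon. For the measured compounds named here, none of the measured steps addresses this exchange directly. Going by the values given here, the only step available, from compound 2 to compound 3, concerns substitution on the piperidine rather than its replacement, and it was modest in size. The replacement of the whole ring attachment by a sulfur-linked carbocycle is a larger change than that, so the expected outcome in this assay is uncertain, and a step in either direction that could exceed the scatter cannot be excluded. Compound 4 is estimated to give 20 nM in this assay, with a range from 5 nM to 80 nM, corresponding to an expected step of a 1.5-fold higher number from compound 2 to compound 4 (0.18 log units; within the scatter).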

Compound 4, half-maximal effective concentration: 69.3 nM
The estimate for compound 4 lay 3.5-fold (0.54 log units) below the measured number; low and high end bracket the measured number.
By their numbers in this assay, from the lowest: compound 3; then compound 2; then compound 4.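

In this assay, the exchange on the aromatic carbon next to the ring nitrogen gives a 5.3-fold higher number from compound 2 to compound 4 (0.72 log units; beyond the scatter), a step that runs in the opposite direction to a 2.3-fold lower number from compound 2 to compound 3 (0.36 log units; beyond the scatter) and is the larger of the two. The earlier steps shown here showed only what a benzyl on the saturated ring does, whereas this one shows that the number also responds to what joins the ring to the aromatic carbon and to what the ring is made of, while compound 4 still gives a number and is not reported as inactive like compound 1. No measurement is available here that would account for this difference in the number.

The single exchange replaces the ring nitrogen attachment with a sulfur link and the piperidine ring with a carbon-only ring at the same time, so the compounds shown cannot assign the step to either change. A cyclohexyl group joined through an oxygen or through an amine nitrogen at this position would separate the two, and a benzyl on the cyclohexyl ring would test whether the step from compound 2 to compound 3 carries over.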